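Permeability of an oxazole-piperidine amide series

A few compounds are considered here, and "the series" means these few. Any claim that something is new, unique, unknown or untested is made for them only; others in the source may bear on it.

Measured compounds:
compound 1 `Cc1cc(C)c(-c2nc(CN3CCC(C(=O)NCCCN4C[C@H](C)C[C@H](C)C4)CC3)c(C)o2)c(C)c1` — "not determined" (no result reported)
compound 2 `Cc1ccccc1-c1nc(CN2CCC(C(=O)NCCCN3CC(C)(C)CC(C)(C)C3)CC2)c(C)o1` — > 1390 10^-6 cm/s
compound 3 `Cc1ccccc1-c1nc(CN2CCC(C(=O)NCCCCN3C[C@H](C)C[C@H](C)C3)CC2)c(C)o1` — 288 10^-6 cm/s

Three compounds share one core and were studied in a physicochemical assay for permeability, using PAMPA; on this read-out higher numbers stand for higher permeability and lower numbers for lower permeability. For compound 1 the result is "not determined" (no result reported), so it has no number of its own. Compound 2 gives > 1390 10^-6 cm/s, which is a limit of the assay and not a number. Compound 3 gives 288 10^-6 cm/s. Within the data shown here, the only step between measured compounds is an at least 4.8-fold lower number from compound 2 to compound 3 (0.68 log units; beyond the scatter), and it concerns the six-membered ring at the far end of the chain, not the aryl group.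

Compound 4 `COc1ccc(-c2nc(CN3CCC(C(=O)NCCCN4C[C@H](C)C[C@H](C)C4)CC3)c(C)o2)cc1OC` is not yet measured. It differs from compound 1 as follows: 3,4-dimethoxyphenyl in place of 2,4,6-trimethylphenyl on an aromatic carbon. No measured step touches this part of the molecule, so the direction of the change cannot be read from the steps shown; the value of compound 3, which carries the same six-membered ring as compound 1 and compound 4, is the nearest anchor, and the one limit of > 1390 10^-6 cm/s in this assay, at which 1 of the 3 values shown sits, shows that the assay can also top out.

Among the measured compounds shown here, compound 4 is therefore expected to give about 150 10^-6 cm/s in this assay, between 40 10^-6 cm/s and 600 10^-6 cm/s, with the range wide because no step speaks to the aryl change.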

Compound 4, apparent permeability: 81.9 10^-6 cm/s
Compound 4: the middle estimate sits 1.8-fold (0.26 log units) above what was measured; measured number inside the range.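

Among these compounds, compound 1, the one compound that differs from compound 4 in a single place, has no number in this assay, so no new step can be read from the result for compound 4. From the compounds shown here alone, whether 3,4-dimethoxyphenyl in place of 2,4,6-trimethylphenyl raises or lowers the number stays open. Nothing shown here accounts for the result for compound 4.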